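This account rests on a few compounds, and the source may have more. Where it says the series, first, only, none or still open, it means among the compounds named here.

Two compounds share one core and differ only in the group on the sulfonyl sulfur. Compound 1 `N#Cc1cc2c(nc1N1CCC(C(=O)NS(=O)(=O)Cc3cc(Cl)cc(Cl)c3)CC1)COC2=O` carries a 3,5-dichlorobenzyl there; in a functional assay (Platelet, plasma) for inhibition, with Homo sapiens as the target (on this read-out higher numbers stand for weaker inhibition and lower numbers for stronger inhibition), compound 1 gives 30500 nM. Compound 2 `N#Cc1cc2c(nc1N1CCC(C(=O)NS(=O)(=O)c3ccc(Cl)s3)CC1)COC2=O` carries a 5-chlorothiophen-2-yl instead, and in this assay compound 2 gives 4470 nM. That single swap brought a 6.8-fold lower number from compound 1 to compound 2 (0.83 log units; beyond the scatter), so compound 2 stands as the lower of the two numbers.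

Compound 3 `Cc1ccc(CS(=O)(=O)NC(=O)C2CCN(c3nc4c(cc3C#N)C(=O)OC4)CC2)cc1` returns to a benzyl-type group: 4-methylbenzyl in place of 5-chlorothiophen-2-yl on a sulfonyl sulfur. Among the measured compounds shown here, the only step that bears on this is the one from compound 1 to compound 2, where giving up a benzyl for the thiophene lowered the number; undoing that kind of change is therefore expected to raise it. The number for compound 3 is expected to rise by a 4.5-fold higher number from compound 2 to compound 3 (0.65 log units; beyond the scatter), landing near compound 1. Compound 3 is estimated at 20000 nM, within 6000 nM to 60000 nM.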

Compound 3, half-maximal inhibitory concentration: 4280 nM
Compound 3: the middle estimate sits 4.7-fold (0.67 log units) above what was measured; the measured number lies below the stated range.
By their numbers in this assay, from the lowest: compounds 3 and 2 (each within the scatter of the next); then compound 1.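

A benzyl-type group on the sulfonyl sulfur does not by itself go with the higher number of compound 1: in this assay, 4-methylbenzyl in place of 5-chlorothiophen-2-yl gives (a 1.0-fold lower number from compound 2 to compound 3 (0.02 log units; within the scatter)), so compound 2 and compound 3 cannot be told apart. What separates the two benzyl-type compounds is the ring they carry, with 4-methylphenyl in place of 3,5-dichlorophenyl giving (a 7.1-fold lower number from compound 1 to compound 3 (0.85 log units; beyond the scatter)). Nothing measured here explains either result.

The compounds shown leave open what a plain benzyl with no ring substituent would give, so the step between the two benzyl-type compounds cannot yet be split into losing the chlorines and gaining the methyl. Also open, as far as these compounds go, is what a carboxylic acid or an amine on that ring, or a longer chain on the sulfonyl sulfur, would do.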